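This account rests on a few compounds, and the source may have more. Where it says the series, first, only, none or still open, it means among the compounds named here.

Measured compounds in an in vitro assay on HEK385-7 cells for displacement of a labelled ligand from prostaglandin D2 receptor 2 (Homo sapiens); on this read-out lower numbers stand for stronger inhibition and higher numbers for weaker inhibition:
compound 1 `CCC(c1ccccc1)c1nc(-c2ccc(Cl)cc2)c(CC(=O)O)s1`, 190 nM
compound 2 `O=C(O)Cc1sc(C(c2ccccc2)c2ccc(Cl)cc2)nc1-c1ccc(Cl)cc1`, 45 nM
compound 3 `COc1ccc(C(c2ccccc2)c2nc(-c3ccc(Cl)cc3)c(CC(=O)O)s2)cc1`, 8.4 nM

Compound 3 stands lowest of the three numbers in this assay. Its nearest neighbour is reached by a 5.4-fold lower number from compound 2 to compound 3 (0.73 log units; beyond the scatter), and the furthest by a 23-fold lower number from compound 1 to compound 3 (1.35 log units; beyond the scatter); both steps lie beyond the scatter, so compound 3 is the strongest of the three measured compounds.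

Compound 4 `O=C(O)Cc1sc(C(c2ccccc2)c2ccccn2)nc1-c1ccc(Cl)cc1` differs from compound 3 in one place: pyridin-2-yl in place of 4-methoxyphenyl on a saturated chain carbon bound to two aromatic carbons. Within the data shown here, no measured step makes this exact exchange. Among the measured compounds shown here, two steps bear on the general point that a six-membered aromatic ring on that chain carbon is favourable: a 4.2-fold lower number from compound 1 to compound 2 (0.63 log units; beyond the scatter) and a 23-fold lower number from compound 1 to compound 3 (1.35 log units; beyond the scatter), one modest and one large. A third step, a 5.4-fold lower number from compound 2 to compound 3 (0.73 log units; beyond the scatter), shows that the group carried by that ring shifts the number by a modest amount. Compound 4 keeps an aromatic ring at that position but gives up the methoxy and brings in a ring nitrogen, for which the series holds no measured comparison. A modest move to a higher number is therefore expected, a 4.8-fold higher number from compound 3 to compound 4 (0.68 log units; beyond the scatter), with wide uncertainty. Compound 4 is estimated at 40 nM in this assay, in the range 10 nM to 160 nM.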

Compound 4, half-maximal inhibitory concentration: 810 nM
Beside the measured number, compound 4's estimate is 20-fold (1.31 log units) below it; the measured number lies above the stated range.
By their numbers in this assay, from the lowest: compound 3; then compound 2; then compound 1; then compound 4.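

In this assay a six-membered aromatic ring on the saturated chain carbon bound to two aromatic carbons no longer reads as favourable in itself: pyridin-2-yl in place of 4-methoxyphenyl gives a large loss (a 96-fold higher number from compound 3 to compound 4 (1.98 log units; beyond the scatter)), and pyridin-2-yl in place of 4-chlorophenyl gives another (an 18-fold higher number from compound 2 to compound 4 (1.26 log units; beyond the scatter)). Even ethyl compares well with pyridin-2-yl (a 4.3-fold higher number from compound 1 to compound 4 (0.63 log units; beyond the scatter)), so compound 4 goes against the gain seen for compound 2 and compound 3 over compound 1, and it is now the weakest of the four measured compounds, with every step to it beyond the scatter. No measurement here accounts for the size of this loss.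

Compound 4 combines two changes on that ring, the ring nitrogen and the absence of a methoxy or chloro group, and the compounds shown do not separate them. A plain phenyl at that carbon would isolate the effect of the substituent, while pyridin-3-yl or pyridin-4-yl would show whether the placing of the ring nitrogen matters.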